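Changing the Thioether Arm on a Shared Core

The source may hold more compounds than are shown below. What is called first, only, known or untested is meant among the compounds shown, and "the series" means these compounds.

Measured in a functional assay on HCT-116 cells (Homo sapiens) for inhibition, read by MTT assay, with a stated time of 48 h; on this read-out lower numbers stand for stronger inhibition and higher numbers for weaker inhibition:
Compound 1, `COc1ccc(-n2c(SC)nnc2-c2cc(OC)c(OC)c(OC)c2)cc1`, gives only a limit of the assay, > 60000 nM.
Compound 2, `COc1ccc(-n2c(SCc3ccc(C)cc3)nnc2-c2cc(OC)c(OC)c(OC)c2)cc1`, gives 33300 nM.
Compound 3, `CCOC(=O)CSc1nnc(-c2cc(OC)c(OC)c(OC)c2)n1-c1ccc(OC)cc1`, gives only a limit of the assay, > 60000 nM.

Among the compounds with values here, compound 2 stands as the only value read as a number; the other two sit at the limit of > 60000 nM in this assay, at which 2 of the 3 values shown sit. Compound 4, `COc1ccc(-n2c(SCC(=O)Nc3ccc(Cl)cc3)nnc2-c2cc(OC)c(OC)c(OC)c2)cc1`, differs from compound 2 by (4-chlorophenyl)carbamoyl in place of 4-methylphenyl on a saturated chain carbon bound to a sulfur. Within the data shown here, two measured steps touch the same place: an at least 1.8-fold lower number from compound 1 to compound 2 (0.25 log units; that floor lies within the scatter) and an at least 1.8-fold higher number from compound 2 to compound 3 (0.25 log units; that floor lies within the scatter), each only a floor that lies within the scatter, because the limit of > 60000 nM in this assay, at which 2 of the 3 values shown sit, caps what they can show. Replacing 4-methylphenyl with an arm carrying a ring and a carbonyl points neither clearly up nor down. For compound 4, the expected step is a 1.2-fold higher number from compound 2 to compound 4 (0.08 log units; within the scatter). Compound 4 is expected to give 40000 nM, between 15000 nM and 90000 nM.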

Compound 4, half-maximal inhibitory concentration: > 60000 nM
Compound 4 gave a limit, no number (the forecaster's own chance of this, stated with the estimate: 40%); middle value at least 1.5-fold (0.17 log units) away from the limit.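

The (4-chlorophenyl)carbamoyl arm gives an at least 1.8-fold higher number from compound 2 to compound 4 (0.25 log units; that floor lies within the scatter). An aromatic ring of carbon only on the arm therefore did not by itself yield a number, since compound 4 gives only a limit. The steps among compound 1, compound 3 and compound 4 cannot be read, and the arms cannot be ranked because the values are capped: the limit of > 60000 nM in this assay, at which 3 of the 4 values shown sit.

Going by these compounds, it remains open whether a 4-chlorobenzyl arm or an arm ending in a carboxylic acid on the same sulfur would give a number. On these data alone, it also remains open whether any arm would move the value beyond the scatter from compound 2.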